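Microsomal stability of two analogues and a phenyl-for-methyl variant

A few compounds are considered here, and "the series" means these few. Any claim that something is new, unique, unknown or untested is made for them only; others in the source may bear on it.

Measured compounds:
- compound 1, `C[C@H](Nc1nc(N)nc(N)c1C#N)c1cc2ccc(F)cn2c(=O)c1-c1ccc(F)cc1`: 84%
- compound 2, `C[C@H](Nc1nc(N)nc(N)c1C#N)c1cc(=O)n2cc(F)ccc2c1-c1ccccc1`: "not determined" (no result reported)
- compound 3, `Cc1c([C@H](C)Nc2nc(N)nc(N)c2C#N)c(-c2ccccc2)c(=O)n2cc(F)ccc12`: 85%

In an ADME assay on microsomes from liver (Mus musculus), read by LC-MS, using NADPH, with a stated time of 30 min, tested at 1 uM (on this read-out higher numbers stand for a more stable compound and lower numbers for a less stable compound), compound 1 gives 84%. In this assay compound 2 gives "not determined" (no result reported), so no number is available for it. In this assay, among the measured compounds shown here, compound 3 gives 85%, which lies within the usual scatter of the value of compound 1, so the two cannot be told apart on these numbers; no step between measured compounds is available.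

Compound 4, `C[C@H](Nc1nc(N)nc(N)c1C#N)c1c(-c2ccccc2)c(=O)n2cc(F)ccc2c1-c1ccccc1`, is the next member and has not been measured. It differs from compound 3 as follows: phenyl in place of methyl on an aromatic carbon. Whether such a change shifts the read-out cannot be inferred from a single pair, and both measured numbers sit in the same high region. The step from compound 3 to compound 4 is therefore expected to be small, a number 7 percentage points lower from compound 3 to compound 4 (within the scatter), and not clearly beyond the scatter. Compound 4 is estimated at 78%, with a range from 60% to 92%.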

Compound 4, percent of the compound remaining: 13%
Beside the measured number, compound 4's estimate is 65 percentage points above it; the whole stated range lies above it.
By their numbers in this assay, from the lowest: compound 4; then compounds 1 and 3 (each within the scatter of the next).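

In this assay, among the compounds shown here, phenyl in place of methyl on an aromatic carbon gives a number 72 percentage points lower from compound 3 to compound 4 (beyond the scatter) and is the first single change that can be read. The earlier high values gave no sign of it, but this position, two atoms from the ring nitrogen, is clearly not indifferent to its substituent on this read-out: with phenyl there, compound 4 stands at 13%. Nothing measured here accounts for the fall.

A single pair leaves open whether the read-out falls gradually through ethyl or isopropyl or only once a ring enters at this position. It also leaves open whether a pyridine ring or a phenyl ring bearing a carboxylic acid would behave as phenyl does.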